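Aryl to methylpyridyl exchange on an oxadiazole-bearing lactam core

This account rests on a few compounds, and the source may have more. Where it says the series, first, only, none or still open, it means among the compounds named here.

Compound 1 `O=C1CC(c2nc(-c3ccc(F)cc3)no2)CN1c1ccc(Cl)cc1` gives 1700 nM in an in vitro functional assay on HEK293-A cells for positive allosteric modulation of metabotropic glutamate receptor 5 (Homo sapiens), read by FLIPR and calcium flux; on this read-out higher numbers stand for an effect only at larger amounts of compound and lower numbers for an effect already at smaller amounts.
Compound 2 `COc1cccc(-c2noc(C3CC(=O)N(c4ccc(Cl)cc4)C3)n2)c1` gives 4800 nM in this assay.
Compound 3 `O=C1CC(c2nc(-c3cccc(Cl)c3)no2)CN1c1ccccc1Cl` gives > 10000 nM in this assay, which is a limit of the assay rather than a number.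

Among the two numbers in this assay, compound 2 stands at the higher one; its nearest neighbour is compound 1, and the step of a 2.8-fold higher number from compound 1 to compound 2 (0.45 log units; beyond the scatter) separates them. Compound 3 sits at the limit described by the limit of > 10000 nM in this assay, at which 1 of the 3 values shown sits.

Compound 4 `Cc1cccc(-c2noc(C3CC(=O)N(c4ccc(Cl)cc4)C3)n2)n1` differs from compound 2 in one place: 6-methylpyridin-2-yl in place of 3-methoxyphenyl on an aromatic carbon. For the measured compounds named here, the only measured step that touches the same position is the one from compound 1 to compound 2, where a 3-methoxyphenyl replaced a 4-fluorophenyl and the number in this assay rose modestly. Going by the values given here, no measured pair exchanges a six-membered ring of carbon only for one with a ring nitrogen, so the change to compound 4 has no direct counterpart in the data. The measured step shows that variation on this ring moves the read-out only modestly, and the account therefore expects compound 4 to stay near compound 2, with the step of a 1.0-fold higher number from compound 2 to compound 4 (0.02 log units; within the scatter) not clearly beyond the scatter. Compound 4 is accordingly estimated at 5000 nM in this assay, with a range from 1500 nM to 16000 nM, and the measurement will decide.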

Compound 4, half-maximal effective concentration: > 10000 nM
Compound 4 ended at the assay's limit; the forecaster's own chance of this, stated with the estimate: 25%; middle value at least 2.0-fold (0.30 log units) away from the limit.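

The value of compound 4 is a limit of the assay and not a number, and it is the second such value among the compounds shown: the limit of > 10000 nM in this assay, at which 2 of the 4 values shown sit.

In this assay, the exchange at this position gives an at least 2.0-fold higher number from compound 2 to compound 4 (0.31 log units; beyond the scatter), and set against the 4-fluorophenyl group the same ring gives an at least 5.8-fold higher number from compound 1 to compound 4 (0.76 log units; beyond the scatter), so both steps lie beyond the scatter even though each can be read only as a lower bound. The earlier compounds shown here showed only a change from one ring of carbon only to another, a 2.8-fold higher number from compound 1 to compound 2 (0.45 log units; beyond the scatter), whereas this result shows that on the aromatic carbon between two ring nitrogen atoms a six-membered aromatic ring with a hetero atom also moves the number upward, and it does so from both carbon-only rings.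

From the compounds shown here alone, the true size of the step stays open, as does whether the ring nitrogen or the methyl carries it, since the two enter together in the 6-methylpyridin-2-yl group. A plain pyridin-2-yl group and a 3-methylphenyl group at this position would tell the two apart.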